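A few compounds are considered here, and "the series" means these few. Any claim that something is new, unique, unknown or untested is made for them only; others in the source may bear on it.

Measured compounds: compound 1 `COc1ccc(-c2cc(=O)c3c(OC)cc(OC)cc3n2S(=O)(=O)c2cccc([N+](=O)[O-])c2)cc1`, compound 2 `COc1ccc(-c2cc(=O)c3c(OC)cc(OC)cc3n2S(=O)(=O)c2ccc(C#N)cc2)cc1`, compound 3 `COc1ccc(-c2cc(=O)c3c(OC)cc(OC)cc3n2S(=O)(=O)c2c(F)c(F)c(F)c(F)c2F)cc1`.

In a functional assay on KOPN-8 cells (Homo sapiens) for antiproliferative activity, with a stated time of 72 h (a lower number here means that less compound is needed, a higher number that more compound is needed for the effect), compound 1 gives only a limit, > 39600 nM. Compound 2 gives only a limit too, > 17200 nM. Compound 3 likewise gives only a limit, > 34400 nM, so in this assay compound 3 stands at a limit, as do the two other values shown (the limit of > 34400 nM in this assay, at which 1 of the 3 values shown sits). Compound 4 `COc1ccc(-c2cc(=O)c3c(OC)cc(OC)cc3n2S(=O)(=O)c2cccc(Br)c2)cc1` is not yet measured; the change is 3-bromophenyl in place of 2,3,4,5,6-pentafluorophenyl on a sulfonyl sulfur. For the measured compounds named here, the steps that bear on it, a step that the two limits leave unreadable from compound 1 to compound 3 and a step that the two limits leave unreadable from compound 2 to compound 3, are unreadable in size because each value involved is a limit (the limit of > 17200 nM in this assay, at which 1 of the 3 values shown sits, (the limit of > 39600 nM in this assay, at which 1 of the 3 values shown sits)). No direction can be read from them; a further limit is expected, meaning a step that the limit leaves unreadable from compound 3 to compound 4 of no readable size. Compound 4 is expected at 40000 nM, between 10000 nM and 100000 nM.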

Compound 4, half-maximal effective concentration: > 58600 nM
Compound 4: only a limit was reported; the forecaster's own chance of this, stated with the estimate: 80%; middle value at least 1.4-fold (0.16 log units) away from the limit.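

In this assay compound 4 gives only a limit, and its steps from compound 1, compound 2 and compound 3, also limits, cannot be read. The compounds shown leave open whether any group on the sulfonyl sulfur gives a measurable antiproliferative effect.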